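Swapping the carbamate tail of compound 1 for an aromatic ring

A few compounds are considered here, and "the series" means these few. Any claim that something is new, unique, unknown or untested is made for them only; others in the source may bear on it.

Measured compounds:
compound 1, `Cc1nc(S(C)(=O)=O)ccc1Oc1ncnc(OC2CCN(C(=O)O[C@@H](C)CF)CC2)c1F`, 186 nM
compound 2, `Cc1nc(S(C)(=O)=O)ccc1Oc1ncnc(OC2CCN(C(=O)OC3(C(F)(F)F)COC3)CC2)c1F`, 29.3 nM
compound 3, `Cc1nc(S(C)(=O)=O)ccc1Oc1ncnc(OC2CCN(C(=O)C3CCCC3)CC2)c1F`, 72.8 nM

All three share one core and differ only in the group on the carbonyl carbon attached to the ring nitrogen. In a functional assay on isolated protein for inhibition of Glucose-dependent insulinotropic receptor (Homo sapiens), read by HTRF and cAMP accumulation (on this read-out higher numbers stand for an effect only at larger amounts of compound and lower numbers for an effect already at smaller amounts), compound 1 gives 186 nM, the highest of the three numbers; the others sit lower, compound 3 with 72.8 nM and compound 2 with 29.3 nM.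

Compound 4, `Cc1nc(S(C)(=O)=O)ccc1Oc1ncnc(OC2CCN(C(=O)c3nc(C(C)(C)F)no3)CC2)c1F`, is built from compound 1 by the change (a group of 9 heavy atoms (5 carbon, 2 nitrogen, 1 oxygen, 1 fluorine; one five-membered aromatic ring with 3 hetero atoms) in place of a group of 5 heavy atoms (3 carbon, 1 oxygen, 1 fluorine; no ring), on a carbonyl carbon). For the measured compounds named here, two measured steps bear on this. In the step of a 6.3-fold lower number from compound 1 to compound 2 (0.80 log units; beyond the scatter) the group was exchanged for another ring-bearing group; in the step of a 2.6-fold lower number from compound 1 to compound 3 (0.41 log units; beyond the scatter) a carbon ring was put directly on the carbonyl carbon, as in compound 4. Both steps gave lower numbers, so for compound 4 a modest step to a lower number is expected, roughly a 3.1-fold lower number from compound 1 to compound 4 (0.49 log units; beyond the scatter) in this assay. The expected value for compound 4 is therefore 60 nM, with a range from 20 nM to 180 nM.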

Compound 4, half-maximal effective concentration: 43.4 nM
Compound 4: middle estimate off by 1.4-fold (0.14 log units), on the high side, and the stated range covers the measured number.
By their numbers in this assay, from the lowest: compounds 2, 4 and 3 (each within the scatter of the next, the first and the last beyond it); then compound 1.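

In this assay, an aromatic ring with three hetero atoms on the carbonyl carbon gives a 4.3-fold lower number from compound 1 to compound 4 (0.63 log units; beyond the scatter) and so joins the groups that read lower than the ringless group of compound 1. This position therefore tolerates a third, quite different ring-bearing group, and all three ring-bearing groups shown sit below compound 1, with no exception among these four compounds. The new ring cannot be separated from the other two, since a 1.7-fold lower number from compound 3 to compound 4 (0.22 log units; within the scatter) and a 1.5-fold higher number from compound 2 to compound 4 (0.17 log units; within the scatter) both lie within the scatter, and no supporting evidence explains why such different rings read so closely.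

Going by these compounds, what the fluorine on the side group of the new ring contributes remains open. So does how a phenyl ring or a simple amine on the carbonyl carbon would read in this assay at this position.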